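The source may hold more compounds than are shown below. What is called first, only, known or untested is meant among the compounds shown, and "the series" means these compounds.

In a functional assay on NALM-6 cells (Homo sapiens) for cytotoxicity, read by luminescence and CellTiter-Glo, with a stated time of 3 days (on this read-out lower numbers stand for stronger inhibition and higher numbers for weaker inhibition), three compounds that share one core have been measured so far. Compound 1 `N#Cc1ccc(NC(=O)c2ccc3cccnc3c2O)c(F)c1` gives 370 nM, compound 2 `N#Cc1ccc(NC(=O)c2cc(Br)c3cccnc3c2O)cc1` gives 210 nM, and compound 3 `Cc1cc(C#N)ccc1NC(=O)c1ccc2cccnc2c1O` gives 230 nM. Compound 3 lies within the usual scatter of both compound 1 and compound 2, so these comparisons set no order.

The next structure is compound 4 `N#Cc1ccc(NC(=O)c2ccc3cccnc3c2O)cc1`, with hydrogen in place of methyl on an aromatic carbon. Among the measured compounds shown here, the one measured step at this place is methyl in place of fluoro, a 1.6-fold lower number from compound 1 to compound 3 (0.21 log units; within the scatter), and it stays within the scatter. Compound 2 also carries hydrogen at this place, but it has an added bromine that compound 4 lacks, so it is only an indirect guide.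

No step beyond the scatter is therefore expected in this assay. The expected step is a 1.1-fold higher number from compound 3 to compound 4 (0.05 log units; within the scatter). Compound 4 is estimated at 260 nM, with an expected range of 120 nM to 550 nM.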

Compound 4, half-maximal inhibitory concentration: 130 nM
For compound 4 the middle estimate is 2.0-fold (0.30 log units) above the measured one; the range from low to high includes it.
By their numbers in this assay, from the lowest: compounds 4, 2, 3 and 1 (each within the scatter of the next, the first and the last beyond it).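

In this assay, among the compounds shown here, hydrogen in place of fluoro gives the first step at this place that lies beyond the scatter, though only modestly (a 2.8-fold lower number from compound 1 to compound 4 (0.45 log units; beyond the scatter)), whereas the earlier swap of fluoro for methyl did not. Hydrogen in place of methyl (a 1.8-fold lower number from compound 3 to compound 4 (0.25 log units; within the scatter)) stays within the scatter, as does hydrogen in place of bromo on another aromatic carbon (a 1.6-fold lower number from compound 2 to compound 4 (0.21 log units; within the scatter)), so neither methyl nor bromo can be told apart from hydrogen here. Nothing available explains the difference between fluoro and hydrogen.

At this place the compounds shown cover only hydrogen, fluoro and methyl, so it remains open how an amine, a methoxy group or a longer chain would read. As far as these compounds go, it is also open whether the fluoro result reflects a wider trend, since it rests on a single step.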